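Hydroxy in place of fluoro: from compound 3 to compound 4

The source may report more compounds than this note shows. Statements on the series, on what has been measured and on what is new or still open speak of the compounds shown alone.

Of the compounds shown here, three of a shared core have been tested in a functional assay on HepG2 cells (Homo sapiens) for inhibition, read by MTT assay, with a stated time of 48 h; on this read-out lower numbers stand for stronger inhibition and higher numbers for weaker inhibition. Compound 1 `O=C(CSc1nnc(-c2ccncc2)n1-c1ccccc1)N/N=C/c1ccc(O)cc1` gives only a limit, > 50000 nM, in this assay. Compound 2 `O=C(CSc1nnc(-c2ccncc2)n1-c1ccccc1)N/N=C/c1ccc(Br)cc1` gives 5990 nM, and compound 3 `O=C(CSc1nnc(-c2ccncc2)n1-c1ccccc1)N/N=C/c1ccccc1F` gives 15200 nM, so compound 3 holds the higher of the two numbers shown; the gap is a 2.5-fold higher number from compound 2 to compound 3 (0.40 log units; beyond the scatter).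

Compound 4 `O=C(CSc1nnc(-c2ccncc2)n1-c1ccccc1)N/N=C/c1ccccc1O` has not been measured. It differs from compound 3 by hydroxy in place of fluoro on an aromatic carbon. Among the compounds with values here, two measured steps bear on this exchange: an at least 8.3-fold lower number from compound 1 to compound 2 (0.92 log units; beyond the scatter), and an at least 3.2-fold lower number from compound 1 to compound 3 (0.51 log units; beyond the scatter). In both, taking the hydroxy group away went with a lower number, and the only hydroxy-bearing compound shown is the one sitting at the limit, (the limit of > 50000 nM in this assay, at which 1 of the 3 values shown sits). The present step runs the other way, putting a hydroxy group in where a halogen stood, so a higher number is expected for compound 4 in this assay, a step of a 2.6-fold higher number from compound 3 to compound 4 (0.42 log units; beyond the scatter). Compound 4 is therefore estimated at 40000 nM, with a range from 12000 nM to 120000 nM, and it may well come back as a limit rather than a number.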

Compound 4, half-maximal inhibitory concentration: 11300 nM
Estimate against measurement, compound 4: 3.5-fold (0.55 log units) above; measured number below the stated range.
By their numbers in this assay, from the lowest: compounds 2, 4 and 3 (each within the scatter of the next, the first and the last beyond it). At a limit, above all of these: compound 1.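

In this assay, on an aromatic carbon ortho to a large group, hydroxy and fluoro cannot be told apart, with a 1.3-fold lower number from compound 3 to compound 4 (0.13 log units; within the scatter), so at this place the added hydrogen-bond donor goes with no change beyond the scatter. The earlier compounds had shown hydroxy only as part of 4-hydroxyphenyl, whereas the 2-hydroxyphenyl of compound 4 also stays close to the 4-bromophenyl compound, with a 1.9-fold higher number from compound 2 to compound 4 (0.28 log units; within the scatter). The step of an at least 4.4-fold lower number from compound 1 to compound 4 (0.64 log units; beyond the scatter) starts from a limit and shows that a hydroxy group does not by itself put a compound at that limit, since among the compounds shown only compound 1, with its 4-hydroxyphenyl, remains there: the limit of > 50000 nM in this assay, at which 1 of the 4 values shown sits.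

The compounds shown leave open whether an amine, a methoxy group or a carboxylic acid at this same place would also stay level with fluoro and hydroxy, or whether the tolerance ends with these small groups. They also leave the halogen and its place tied together, since a 2-bromophenyl or 4-fluorophenyl compound would be needed to separate the two changes that lie between compound 2 and compound 3.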